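The source may hold more compounds than are shown below. What is called first, only, known or untested is meant among the compounds shown, and "the series" means these compounds.

Measured in a functional assay on HT-22 cells (Mus musculus), read by MTT assay, with a stated time of 24 h; on this read-out lower numbers stand for an effect already at smaller amounts and higher numbers for an effect only at larger amounts of compound:
- compound 1 `COc1ccc(-c2cc(OC)c3ccccc3n2)cc1O`: "not active" (no number reported)
- compound 2 `COc1cc(-c2ccc(O)c(O)c2)nc2ccccc12`: 40 nM

Among the measured compounds shown here, compound 2 holds the only number so far, as compound 1 gave no number at all. Compound 3 `COc1cc(-c2ccc([N+](=O)[O-])c(O)c2)nc2ccccc12`, not yet measured, carries nitro in place of hydroxy on an aromatic carbon, ortho to a hydroxy group: nitro in place of hydroxy on an aromatic carbon. For the measured compounds named here, no measured pair shows what such a change does. Going by the values given here, the only guide is that compound 2 gives 40 nM while compound 1 gives "not active" (no number reported), so a loss seems more likely than a gain. A clear move to higher numbers in this assay is expected, estimated as a 13-fold higher number from compound 2 to compound 3 (1.10 log units; beyond the scatter). For compound 3 the expected value is 500 nM, with an estimated range of 60 nM to 4000 nM.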

Compound 3, half-maximal effective concentration: "not active" (no number reported)
Nothing numeric was reported for compound 3; there is nothing to compare the estimate with.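

Among the compounds shown here, compound 3 has no number in this assay and no step from compound 2 to compound 3 can be read. Going by these compounds, how far nitro in place of hydroxy shifts the value stays open. No measurement shown points to a cause.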